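The source may report more compounds than this note shows. Statements on the series, on what has been measured and on what is new or still open speak of the compounds shown alone.

Compound 2 `CCCCCc1ccc(C#Cc2cn(C/C=C\CN3C(=O)c4ccccc4C3=O)c(=O)[nH]c2=O)cc1` carries a pentyl chain on an aromatic carbon and a double bond drawn Z in the linker. In a functional assay on MCF7 cells (Homo sapiens) for antiproliferative activity, read by MTT assay, with a stated time of 3 days (on this read-out lower numbers stand for stronger inhibition and higher numbers for weaker inhibition), compound 2 gives only a limit, > 100000 nM. Its methyl counterpart, compound 1 `Cc1ccc(C#Cc2cn(C/C=C\CN3C(=O)c4ccccc4C3=O)c(=O)[nH]c2=O)cc1`, in this assay likewise gives only a limit, > 100000 nM. The isomer drawn E, compound 3 `CCCCCc1ccc(C#Cc2cn(C/C=C/CN3C(=O)c4ccccc4C3=O)c(=O)[nH]c2=O)cc1`, gives 5600 nM in this assay. The step that the two limits leave unreadable from compound 1 to compound 2 cannot be read because both values sit at the limit of > 100000 nM in this assay, at which 2 of the 3 values shown sit, while the step of an at least 17-fold lower number from compound 2 to compound 3 (1.25 log units; beyond the scatter) concerns the double bond rather than the chain. Compound 4 `CCCCc1ccc(C#Cc2cn(C/C=C\CN3C(=O)c4ccccc4C3=O)c(=O)[nH]c2=O)cc1` differs from compound 2 by hydrogen in place of methyl on a saturated chain carbon, four bonds along the chain from an aromatic carbon, pentyl shortened to butyl with the Z drawing kept. Only the unreadable chain step bears on this change, so compound 4 is expected to stay at the limit, a number no higher from compound 2 to compound 4 (the limit leaves the size open). The estimate for compound 4 is 100000 nM, between 30000 nM and 300000 nM.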

Compound 4, half-maximal inhibitory concentration: 43000 nM
Compound 4: the middle estimate sits 2.3-fold (0.37 log units) above what was measured, within the range that was stated.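

Compound 4 shows that the series with the Z drawing can leave the limit in this assay with the double bond unchanged. Shortening pentyl to butyl gives an at least 2.3-fold lower number from compound 2 to compound 4 (0.36 log units; beyond the scatter) and, set against methyl, butyl gives an at least 2.3-fold lower number from compound 1 to compound 4 (0.36 log units; beyond the scatter) as a second readable step. Among compound 1, compound 2 and compound 4, the number therefore does not move steadily with chain length, though the step between the two limits still cannot be read. From the compounds shown here alone, it remains open how a propyl chain or a hexyl chain would read here, and how butyl would read with the double bond drawn E.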